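The source may report more compounds than this note shows. Statements on the series, on what has been measured and on what is new or still open speak of the compounds shown alone.

Series notes. In an assay on HeLa cells for inhibition of Indoleamine 2,3-dioxygenase 1 (Homo sapiens) (on this read-out lower numbers stand for stronger inhibition and higher numbers for weaker inhibition), compound 1 `O=C(OC1CC1)N1CCc2cc(C3(C(=O)Nc4ccc(F)cc4)CCC3)ccc21` gives 1.4 nM. Compound 2 `O=C(Nc1ccc(Cl)cc1)C1(c2ccc3c(c2)CCN3c2ccccn2)CCC1` gives 1.6 nM in this assay, and compound 3 `CCN(C(=O)N1CCc2cc(C3(C(=O)Nc4ccc(Cl)cc4)CCC3)ccc21)C(C)C` gives 3.3 nM. Compound 2 stands second highest of the three numbers; its nearest neighbour is compound 1, within the scatter, and its furthest is compound 3, beyond it. Among the compounds with values here, the only single-place step measured so far is a 2.1-fold higher number from compound 2 to compound 3 (0.31 log units; beyond the scatter), a change at the nitrogen of the core, not at the anilide.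

Compound 4 `O=C(Nc1ccc(F)cc1)C1(c2ccc3c(c2)CCN3c2ccccn2)CCC1` keeps the core of compound 2 and differs by fluoro in place of chloro on an aromatic carbon. Within the data shown here, no measured step bears directly on this exchange. Compound 1 at 1.4 nM carries fluoro on the anilide, while compound 3 at 3.3 nM carries chloro there, but these two also differ at the ring nitrogen, so their values speak only for the pair of changes taken together. The step of a 2.1-fold higher number from compound 2 to compound 3 (0.31 log units; beyond the scatter) concerns another position and shows the series moving within a narrow band in this assay.

For compound 4 the expected step is a 1.3-fold higher number from compound 2 to compound 4 (0.10 log units; within the scatter), meaning no change beyond the scatter is anticipated. Compound 4 is therefore estimated at 2 nM, with a range from 0.8 nM to 5 nM.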

Compound 4, half-maximal inhibitory concentration: 3.1 nM
The estimate for compound 4 lay 1.6-fold (0.19 log units) below the measured number; low and high end bracket the measured number.
By their numbers in this assay, from the lowest: compounds 1, 2, 4 and 3 (each within the scatter of the next, the first and the last beyond it).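

In this assay, fluoro in place of chloro on an aromatic carbon, para to a large group, can now be read directly as a 1.9-fold higher number from compound 2 to compound 4 (0.29 log units; within the scatter), so with pyridin-2-yl on the core nitrogen this exchange does not separate compound 2 from compound 4. The new pair with fluoro held constant adds a 2.2-fold higher number from compound 1 to compound 4 (0.35 log units; beyond the scatter), a modest step beyond the scatter. The two structures of this pair differ on the core nitrogen, as do those of a 2.1-fold higher number from compound 2 to compound 3 (0.31 log units; beyond the scatter) with chloro held constant. No supporting measurement on hand accounts for either the halogen step or the nitrogen steps.

On these data alone, the halogen exchange has been read only with pyridin-2-yl on the nitrogen, so its size with cyclopropyloxycarbonyl or ethyl(isopropyl)carbamoyl there remains open. Also open, as far as these compounds go, is how far the same para position on the 4-fluorophenyl ring would hold this narrow band with a different kind of group, such as methoxy, a nitrile or a carboxylic acid.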